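A few compounds are considered here, and "the series" means these few. Any claim that something is new, unique, unknown or untested is made for them only; others in the source may bear on it.

Measured in a functional assay on ZR-75-1 cells (Homo sapiens) for inhibition, read by sulforhodamine B assay; on this read-out higher numbers stand for weaker inhibition of growth and lower numbers for stronger inhibition of growth:
- compound 1 `CN(C)c1ccc(-c2ccc(-c3ccc(-c4nc5ccccc5[nH]4)cc3)cc2)cc1`: 100000 nM
- compound 2 `Oc1cccc2[nH]c(-c3ccc(-c4ccc(-c5ccc(F)cc5)cc4)cc3)nc12`: 6320 nM
- compound 3 `Oc1cccc2[nH]c(-c3ccc(-c4ccc(-c5ccc(OC(F)(F)F)cc5)cc4)cc3)nc12`: 3800 nM

Compound 3 and compound 2 lie within the scatter of each other, so neither can be ranked ahead. Compound 1, at 100000 nM, stands well beyond the scatter from compound 3.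

The next compound is compound 4 `CN(C)c1ccc(-c2ccc(-c3ccc(-c4nc5c(O)cccc5[nH]4)cc3)cc2)cc1`, with dimethylamino in place of trifluoromethoxy on an aromatic carbon, para to a large group: dimethylamino in place of trifluoromethoxy on an aromatic carbon. Going by the values given here, the only measured step at this place is a 1.7-fold lower number from compound 2 to compound 3 (0.22 log units; within the scatter), which stays within the scatter, so one earlier exchange of this substituent moved this assay very little. That is thin evidence from a single pair. Compound 1 carries the same dimethylamino group but lacks the hydroxyl of compound 3, so its high number cannot be assigned to either difference. Among the compounds with values here, no measured pair separates the two, and some risk of a higher number for compound 4 remains.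

The expected result is a 1.3-fold higher number from compound 3 to compound 4 (0.12 log units; within the scatter), which means no expected change beyond the scatter. For compound 4 the estimate is 5000 nM, with an expected range of 1500 nM to 30000 nM.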

Compound 4, concentration for 50% growth inhibition: 4100 nM
Estimate against measurement, compound 4: 1.2-fold (0.09 log units) above; the range from low to high includes it.
By their numbers in this assay, from the lowest: compounds 3, 4 and 2 (each within the scatter of the next); then compound 1.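

In this assay, with the hydroxy group kept, the exchange on the aromatic carbon para to a large group still shows no effect: dimethylamino in place of trifluoromethoxy gives a 1.1-fold higher number from compound 3 to compound 4 (0.03 log units; within the scatter) and dimethylamino in place of fluoro gives a 1.5-fold lower number from compound 2 to compound 4 (0.19 log units; within the scatter). Fluoro, trifluoromethoxy and dimethylamino therefore cannot be told apart at this place, and this now holds for a group with a different enters-and-leaves count of atoms as well as for the earlier single pair. Going by these compounds alone, the large change lies elsewhere: hydroxy in place of hydrogen on an aromatic carbon gives a 24-fold lower number from compound 1 to compound 4 (1.39 log units; beyond the scatter), the first measured pair to separate the two differences that compound 1 carried, so its high number goes with the missing hydroxy group and not with dimethylamino.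

Still open, on these data alone, is whether a methoxy group or an amine could stand in place of the hydroxy group and keep this gain, and whether the gain is the same size with fluoro or trifluoromethoxy at the outer position. No measurement at hand explains the size of the hydroxy step or the flatness of the outer exchange.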